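Trifluoromethyl to fluoro: working notes on the series

The source may report more compounds than this note shows. Statements on the series, on what has been measured and on what is new or still open speak of the compounds shown alone.

Values in a functional assay on HepG2 cells (Homo sapiens) for inhibition, read by MTT assay, with a stated time of 72 h (on this read-out lower numbers stand for stronger inhibition and higher numbers for weaker inhibition), for the measured compounds
- compound 1 `Cc1ccc(NC(=O)C2CCN(C/C=C/c3ccccc3)CC2)cc1` gives 33900 nM
- compound 2 `COc1ccc(NC(=O)C2CCN(C/C=C/c3ccccc3)CC2)cc1` gives 88800 nM
- compound 3 `O=C(Nc1cccc(C(F)(F)F)c1)C1CCN(C/C=C/c2ccccc2)CC1` gives 11400 nM

Compound 3 has the lowest number of the three, beyond the scatter from both others. Compound 4 `O=C(Nc1cccc(F)c1)C1CCN(C/C=C/c2ccccc2)CC1` keeps the shared core and carries fluoro in place of trifluoromethyl on an aromatic carbon at the same place. Among the measured compounds shown here, no measured step covers this swap. For the measured compounds named here, the only guide to size is a 2.6-fold higher number from compound 1 to compound 2 (0.42 log units; beyond the scatter) for a different swap on an aromatic carbon, and that step is modest. A modest rise in this assay is therefore expected, and the expected step is a 2.0-fold higher number from compound 3 to compound 4 (0.30 log units; within the scatter) in this direction. Compound 4 is estimated at 23000 nM (expected range 9000 nM to 55000 nM).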

Compound 4, half-maximal inhibitory concentration: 51100 nM
For compound 4 the middle estimate is 2.2-fold (0.35 log units) below the measured one, and the stated range covers the measured number.
By their numbers in this assay, from the lowest: compound 3; then compounds 1, 4 and 2 (each within the scatter of the next, the first and the last beyond it).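

At this aromatic carbon, meta to a large group, fluoro in place of trifluoromethyl gives a clear rise in this assay (a 4.5-fold higher number from compound 3 to compound 4 (0.65 log units; beyond the scatter)). 3-Fluorophenyl on the amide-type nitrogen does not separate from 4-methylphenyl (a 1.5-fold higher number from compound 1 to compound 4 (0.18 log units; within the scatter)) or 4-methoxyphenyl (a 1.7-fold lower number from compound 2 to compound 4 (0.24 log units; within the scatter)), leaving compound 3 alone beyond the scatter from all the others. Nothing available bears on the reason for this step.

On these data alone, how a nitrile, a carboxylic acid or an amine on this aromatic carbon would compare with trifluoromethyl stays open. As far as these compounds go, whether the step carries over to a different core also stays open.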